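The compounds below may be only part of what the source reports. "The series", "measured", "known", "first", "only" and "open" are said of these compounds alone.

The series is followed in a functional assay on Jurkat cells (Homo sapiens) for inhibition, read by MTT assay, with a stated time of 72 h; a lower number here means a stronger inhibitor of growth, a higher number a weaker inhibitor of growth. Compound 1 `COC(=O)c1nc(C)n(-c2cccc(C(F)(F)F)c2)n1` gives 10600 nM. Compound 2 `COC(=O)c1nc(C)n(-c2ccc(OC)cc2)n1` returns only a limit of the assay, > 100000 nM. One of the three values shown thus sits at the limit of > 100000 nM in this assay, at which 1 of the 3 values shown sits. Compound 3 `CCc1nc(C(=O)OC)nn1-c1ccc(F)cc1` gives 11000 nM in this assay; of the two numbers shown, the one for compound 3 and the one for compound 1 lie within the scatter of each other, so neither can be placed ahead of the other.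

Compound 4 `COC(=O)c1nc(-c2ccsc2)n(-c2ccc(F)cc2)n1` has not yet been measured. It differs from compound 3 in one place: thiophen-3-yl in place of ethyl on an aromatic carbon. Among the measured compounds shown here, no two measured compounds differ in a single place, so no measured step guides the expectation, and the three measured compounds vary at more than one position at once. In this assay the step is expected to be a 1.4-fold lower number from compound 3 to compound 4 (0.14 log units; within the scatter), within the scatter, with only a slight lean toward a lower number. Compound 4 is accordingly expected to give about 8000 nM in this assay, with a likely range from 2000 nM to 40000 nM.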

Compound 4, concentration for 50% growth inhibition: 54000 nM
Beside the measured number, compound 4's estimate is 6.8-fold (0.83 log units) below it; the measured number lies above the stated range.
By their numbers in this assay, from the lowest: compounds 1 and 3 (each within the scatter of the next); then compound 4. At a limit, above all of these: compound 2.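

Thiophen-3-yl in place of ethyl on the aromatic carbon between two ring nitrogen atoms gives a 4.9-fold higher number from compound 3 to compound 4 (0.69 log units; beyond the scatter) in this assay. Among the compounds shown here, this is the first reading of a change at a single place, and it shows that this position is not indifferent to its group: for this pair, the ring of 5 heavy atoms gives weaker growth inhibition than the ethyl chain of 2 heavy atoms. Nothing shown here gives a reason for this step.

The compounds shown leave open whether the ring itself or thiophen-3-yl in particular sets this step, which a phenyl ring, a propyl chain or an amine on the same carbon could separate. On these data alone, whether the step would hold with the trifluoromethyl group of compound 1 in place of the fluorine of compound 3 also remains open.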